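This account rests on a few compounds, and the source may have more. Where it says the series, first, only, none or still open, it means among the compounds named here.

Compound 1 `CN(Cc1ccccc1OCCC[C@@H]1C[C@@H]1C(=O)O)C(=O)c1ccc(-c2ccco2)cc1`: 2.7 h
Compound 2 `C/C(=C\CCCOc1ccccc1CN(C)C(=O)c1ccc(-c2ccco2)cc1)C(=O)O`: 1.2 h

In an ADME assay on the whole organism (strain CD-1) for metabolic stability, with Mus musculus as the target, at a dose of 3 mg/kg by the intravenous route (on this read-out higher numbers stand for a longer-lived compound and lower numbers for a shorter-lived compound), compound 2 is the lower of the two measured compounds, at 1.2 h. Compound 3 `C/C(=C\COc1ccccc1CN(C)C(=O)c1ccc(-c2ccco2)cc1)CCC(=O)O` has the same atoms joined differently, with 4-carboxy-2-methylbut-1-en-1-yl in place of 4-carboxypent-3-en-1-yl on a saturated chain carbon bound to an oxygen on an aromatic ring. Among the compounds with values here, only one measured step bears on this: a 2.3-fold lower number from compound 1 to compound 2 (0.35 log units; beyond the scatter). It was modest and involved a different change, so it gives no direction here. The expected result is no change beyond the scatter, an estimated 1.1-fold lower number from compound 2 to compound 3 (0.04 log units; within the scatter). For compound 3 the estimate is 1.1 h, with an expected range of 0.5 h to 2.4 h.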

Compound 3, half-life: 2.3 h
Beside the measured number, compound 3's estimate is 2.1-fold (0.32 log units) below it, within the range that was stated.
By their numbers in this assay, from the lowest: compounds 2, 3 and 1 (each within the scatter of the next, the first and the last beyond it).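

In this assay, rearranging the same atoms in the chain gives a 1.9-fold higher number from compound 2 to compound 3 (0.28 log units; within the scatter), so this shift of the methyl group and double bond cannot be separated from ordinary scatter. The open chain of compound 3 also gives a 1.2-fold lower number from compound 1 to compound 3 (0.07 log units; within the scatter), which means that, unlike compound 2, it stays within the scatter of the cyclopropane-bearing compound 1. Nothing available explains these numbers. Still open, on these data alone, is how the half-life would respond to a longer chain between the ring oxygen and the carboxylic acid, or to a tetrazole in place of that acid.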